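The source may hold more compounds than are shown below. What is called first, only, known or untested is meant among the compounds shown, and "the series" means these compounds.

Working notes on the series.

Three compounds have been run in a functional assay on HCT-8 cells (Homo sapiens) for antiproliferative activity, read by MTT assay, with a stated time of 48 h; on this read-out lower numbers stand for stronger inhibition and higher numbers for weaker inhibition. Compound 1, `C=C(c1ccc2c(c1)C=CC(C)(C)O2)c1ccc(OC)cc1NC(=O)CNC`, gives 590 nM. Compound 2, `C=C(c1ccc2c(c1)C=CC(C)(C)O2)c1ccc(OC)cc1NC(=O)CNCC`, gives 2220 nM. Compound 3, `C=C(c1cc(OC)c(OC)c(OC)c1)c1ccc(OC)c(O)c1NC(=O)COC`, gives 280 nM, the lowest number of the three, and its gaps to compound 1 and to compound 2 both lie beyond the usual scatter. The difference between the core of compound 3 and the core of compound 1 is not broken down here.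

One change is seen within the measured set. Between compound 1 and compound 2 it reads (methyl in place of hydrogen on a saturated chain carbon bound to an amine nitrogen), and it produced a 3.8-fold higher number from compound 1 to compound 2 (0.58 log units; beyond the scatter).

Compound 4, `C=C(c1cc(OC)c(OC)c(OC)c1)c1ccc(OC)c(O)c1NC(=O)COCC`, has not yet been measured. It differs from compound 3 by methyl in place of hydrogen on a saturated chain carbon bound to an oxygen on a saturated carbon. Within the data shown here, this is the same kind of change as the one from compound 1 to compound 2, not the same: there the place was on a saturated chain carbon bound to an amine nitrogen, here it is on a saturated chain carbon bound to an oxygen on a saturated carbon, and the core is the core of compound 3 rather than that of compound 1.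

Given that the only comparable step on record, a 3.8-fold higher number from compound 1 to compound 2 (0.58 log units; beyond the scatter), went toward a higher number, the expectation for compound 4 is a step of a 2.5-fold higher number from compound 3 to compound 4 (0.40 log units; beyond the scatter) in this assay, somewhat smaller than that earlier step since the place differs. Compound 4 is therefore estimated at 700 nM, with a likely range from 300 nM to 1800 nM.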

Compound 4, half-maximal inhibitory concentration: 910 nM
Compound 4: middle estimate off by 1.3-fold (0.11 log units), on the low side, within the range that was stated.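

In this assay, the change from methoxymethyl to ethoxymethyl gave a 3.3-fold higher number from compound 3 to compound 4 (0.51 log units; beyond the scatter), in the same direction as the earlier step on the core of compound 1, where the added methyl stood on a saturated chain carbon bound to an amine nitrogen. Set side by side, the two steps do not differ beyond the scatter, so in this series the added methyl carries over from one core to the other with much the same size of step: the same change on two cores in this assay, a 3.8-fold higher number (0.58 log units; beyond the scatter) from compound 1 to compound 2 and a 3.3-fold higher number (0.51 log units; beyond the scatter) from compound 3 to compound 4, 1.2-fold (0.06 log units) apart, within the scatter of two such steps. Among these compounds, this rests on only two pairs, which differ in the core and also in the atom the chain carbon is bound to, so it neither separates the part played by the core from that played by the chain, nor shows why the number rises, nor shows that the step would hold on any further core.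

The compounds shown leave open how a longer chain such as propyl or a branched chain such as isopropyl would read at this place on either core. They also leave open how each side chain would read on the other core, and whether a free primary amine or a carboxylic acid at this place would follow the same direction.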